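Propargyl to Fluorobenzyl Thioether on Two Amide Cores

A few compounds are considered here, and "the series" means these few. Any claim that something is new, unique, unknown or untested is made for them only; others in the source may bear on it.

The study compares three measured amides. Compound 1 `C#CCSC[C@H](NC(=O)c1cc(OC)c(OC)c(OC)c1)C(=O)OC` gives 53200 nM in an assay on RAW264.7 cells for antagonist activity at Toll-like receptor 2 (Mus musculus), read by Griess assay, with a stated time of 24 h; a higher number here means a weaker inhibitor, a lower number a stronger inhibitor. Compound 2 `COC(=O)[C@H](CSCc1ccc(F)cc1)NC(=O)c1cc(OC)c(OC)c(OC)c1` differs from it by 4-fluorophenyl in place of ethynyl on a saturated chain carbon bound to a sulfur, and in this assay compound 2 gives 28600 nM; the step of a 1.9-fold lower number from compound 1 to compound 2 (0.27 log units; within the scatter) is a small one. Compound 3 `C#CCSC[C@H](NC(=O)c1cc(O)cc(O)c1)C(=O)OC` carries a different core, and how that core differs from the core of compound 1 is not broken down here. In this assay compound 3 gives 41800 nM, a number lying within the scatter of both compound 1 and compound 2, so the three measured values are not distinguished from one another.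

Compound 4 `COC(=O)[C@H](CSCc1ccc(F)cc1)NC(=O)c1cc(O)cc(O)c1` has not yet been measured. It differs from compound 3 by 4-fluorophenyl in place of ethynyl on a saturated chain carbon bound to a sulfur, the same change that turns compound 1 into compound 2 at the same place. Going by the values given here, because that change earlier gave a 1.9-fold lower number from compound 1 to compound 2 (0.27 log units; within the scatter), a step of similar size is expected here, a 1.9-fold lower number from compound 3 to compound 4 (0.28 log units; within the scatter), and nothing among the measured compounds points to a larger shift. On that basis compound 4 is estimated at 22000 nM in this assay, with an expected range from 10000 nM to 50000 nM.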

Compound 4, half-maximal inhibitory concentration: 38400 nM
For compound 4 the middle estimate is 1.7-fold (0.24 log units) below the measured one; the measured number falls inside the stated range.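

On the core of compound 3, propargyl to 4-fluorobenzyl gives, in this assay, a 1.1-fold lower number from compound 3 to compound 4 (0.04 log units; within the scatter), a step too small to separate the two compounds. Set beside the earlier step, the change reads alike on the two cores as far as these numbers can tell: the same change on two cores in this assay, a 1.9-fold lower number (0.27 log units; within the scatter) from compound 1 to compound 2 and a 1.1-fold lower number (0.04 log units; within the scatter) from compound 3 to compound 4, 1.7-fold (0.23 log units) apart, within the scatter of two such steps. Going by these compounds alone, that agreement shows only that the two steps cannot be told apart; neither step lies beyond the scatter, so the pair does not show that the change moves the number on either core, nor that any real effect carries over from one core to another.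

The compounds shown leave open whether a different group in place of the propargyl, such as an amine, a carboxylic acid or a longer alkyl chain, would give a step beyond the scatter. They also leave open whether propargyl to 4-fluorobenzyl would read the same on any core other than these two.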